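The compounds below may be only part of what the source reports. "The series", "measured", "known", "first", "only" and "open" are said of these compounds alone.

Compound 1 `C=C1CC[C@@H]2[C@](C)(CCC[C@]2(C)C(=O)O)[C@H]1CC/C(C)=C/CO` and compound 2 `C=C[C@@]1(C)O[C@H]1C[C@H]1C(=C)CC[C@@H]2[C@]1(C)CCC[C@]2(C)C(=O)O` both leave a functional assay on MCF7 cells (Homo sapiens) for cytotoxicity, read by MTT assay, with a stated time of 48 h (on this read-out higher numbers stand for weaker inhibition and lower numbers for stronger inhibition), without a number. In this assay compound 1 gives > 40000 nM, a limit of the assay and not a number. In this assay compound 2 gives > 40000 nM, likewise a limit and not a number. Within the data shown here, the one measured step, a step that the two limits leave unreadable from compound 1 to compound 2, has no readable size; both values rest at the limit of > 40000 nM in this assay, at which 2 of the 2 values shown sit. Compound 2 therefore stands only at that limit, with nothing to place it against compound 1.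

Compound 3 `C=C1CC[C@@H]2[C@](C)(CCC[C@]2(C)C(=O)O)[C@H]1C/C=C(\C)C=O` differs from compound 2 by a group of 5 heavy atoms (4 carbon, 1 oxygen; no ring) in place of a group of 6 heavy atoms (5 carbon, 1 oxygen; one three-membered non-aromatic ring with 1 hetero atom), on a saturated chain carbon bound to a saturated ring carbon. Among the measured compounds shown here, no measured step speaks to this change: the only step in hand, a step that the two limits leave unreadable from compound 1 to compound 2, was left unreadable by the two limits, and it concerned the group that now leaves rather than the group that enters. The measured values give no ground for a step in either direction beyond the scatter. Compound 3 is therefore expected in this assay near the limit again, estimated as 35000 nM within 8000 nM to 40000 nM. On that basis the expected step is an at least 1.1-fold lower number from compound 2 to compound 3 (0.05 log units; that floor lies within the scatter), its direction not settled by the data.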

Compound 3, half-maximal inhibitory concentration: > 40000 nM
Compound 3: a limit, no number; the forecaster's own chance of this, stated with the estimate: 55%; at least 1.1-fold (0.05 log units) between middle value and limit.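

In this assay compound 3 gives > 40000 nM, again a limit and not a number. No step among compound 1, compound 2 and compound 3 can be read: the limit of > 40000 nM in this assay, at which 3 of the 3 values shown sit.

Left open is whether the groups carried on the shared core by these three compounds differ at all in this assay.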